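Methyl for fluoro in a phenyl urea benzoate series

A few compounds are considered here, and "the series" means these few. Any claim that something is new, unique, unknown or untested is made for them only; others in the source may bear on it.

Compound 1 `O=C(Nc1ccccc1)Nc1ccc(OC(=O)c2ccc(F)cc2)cc1` in a functional assay on A549 cells (Homo sapiens) for antiproliferative activity, read by MTT assay, with a stated time of 48 h (on this read-out lower numbers stand for stronger inhibition and higher numbers for weaker inhibition), gives 38500 nM. Compound 2 `Cc1ccc(C(=O)Oc2ccc(NC(=O)Nc3ccccc3)cc2)cc1` carries methyl in place of fluoro on an aromatic carbon and in this assay gives 18900 nM; the step is a 2.0-fold lower number from compound 1 to compound 2 (0.31 log units; beyond the scatter). Compound 3 `O=C(Nc1ccc(F)cc1)Nc1ccc(OC(=O)c2ccccc2)cc1` has the same atoms as compound 1 joined differently; the difference between the two cores is not broken down here. In this assay compound 3 gives 29700 nM, within the scatter of compound 1. Compound 4 `Cc1ccc(NC(=O)Nc2ccc(OC(=O)c3ccccc3)cc2)cc1`, not yet measured, differs from compound 3 by methyl in place of fluoro on an aromatic carbon. This is the same kind of change as from compound 1 to compound 2, though here the wider reading is (4-fluorophenyl)amino to (4-methylphenyl)amino rather than only 4-fluorophenyl to 4-methylphenyl. Since a 2.0-fold lower number from compound 1 to compound 2 (0.31 log units; beyond the scatter) was modest, compound 4 is expected to show a 2.0-fold lower number from compound 3 to compound 4 (0.30 log units; within the scatter). Compound 4 is estimated at 15000 nM, likely between 7000 nM and 32000 nM.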

Compound 4, half-maximal inhibitory concentration: 47700 nM
The estimate for compound 4 lay 3.2-fold (0.50 log units) below the measured number; measured number outside the range, above it.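

In this assay, methyl in place of fluoro on the core of compound 3 gives a 1.6-fold higher number from compound 3 to compound 4 (0.21 log units; within the scatter), so the lower number seen on the core of compound 1 does not recur. The same change therefore reads differently on the two cores: the same change on two cores in this assay, a 2.0-fold lower number (0.31 log units; beyond the scatter) from compound 1 to compound 2 and a 1.6-fold higher number (0.21 log units; within the scatter) from compound 3 to compound 4, 3.3-fold (0.51 log units) apart, beyond the scatter of two such steps This shows that the step on one core does not predict the step on the other for this pair, but a single pair of steps gives no rule for the series and does not show why the two differ.

As far as these compounds go, whether a second swap on each core would also part in this way remains open. So does the behaviour of a chloro, a methoxy or an amine at the same place on either core.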